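The source may report more compounds than this note shows. Statements on the series, on what has been measured and on what is new or still open speak of the compounds shown alone.

Measured in a functional assay on MT4 cells (Homo sapiens) for cytotoxicity; on this read-out lower numbers stand for stronger inhibition and higher numbers for weaker inhibition:

- compound 1, `N#Cc1c(N)cccc1Sc1ccccc1`: 168000 nM
- compound 2, `N#Cc1c(N)cccc1Sc1ccc(Cl)cc1`: 113000 nM
- compound 3, `N#Cc1c(N)cccc1S(=O)(=O)c1cccc(Cl)c1`: > 200000 nM

Compound 1 carries the core shown beside it. Compound 2 differs from it by chloro in place of hydrogen on an aromatic carbon and the step is a 1.5-fold lower number from compound 1 to compound 2 (0.17 log units; within the scatter), so in this assay compound 1 and compound 2 sit within the scatter of each other. Compound 3 belongs to a second core; how it differs from compound 1 is not broken down here. For compound 3 the assay gives only a limit, not a number, the value > 200000 nM standing at the limit of > 200000 nM in this assay, at which 1 of the 3 values shown sits.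

Compound 4, `N#Cc1c(N)cccc1S(=O)(=O)c1cc(Cl)cc(Cl)c1`, is not yet measured. It differs from compound 3 by chloro in place of hydrogen on an aromatic carbon, the same kind of change as from compound 1 to compound 2, though the surroundings differ: in compound 2 the chloro is para to a large group, in compound 4 it is meta to a chloro group and meta to a large group. Resting on the within-scatter step a 1.5-fold lower number from compound 1 to compound 2 (0.17 log units; within the scatter) and on the limit of compound 3, the step that the limit leaves unreadable from compound 3 to compound 4 is expected to stay small. Compound 4 is therefore estimated at about 250000 nM, with a good chance that this assay again reports only a limit.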

Compound 4, half-maximal inhibitory concentration: > 200000 nM
Compound 4: a limit, no number (the forecaster's own chance of this, stated with the estimate: 70%); the middle value is on the limit's open side.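

In this assay compound 4 gives > 200000 nM, a limit and not a number. Compound 3 also gives only a limit, so no step from compound 3 to compound 4 can be read: the limit of > 200000 nM in this assay, at which 2 of the 4 values shown sit.

The compounds shown leave open how large the effect of chloro in place of hydrogen is on the core of compound 3 in this assay.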